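A few compounds are considered here, and "the series" means these few. Any claim that something is new, unique, unknown or untested is made for them only; others in the source may bear on it.

Compounds measured in a functional assay on K562 cells (Homo sapiens), read by MTT assay, with a stated time of 72 h; on this read-out higher numbers stand for weaker inhibition and lower numbers for stronger inhibition:

- Compound 1, `O=c1[nH]cnc2c1c(-c1cccs1)cn2[C@@H]1O[C@H](CO)[C@@H](O)[C@H]1O`: compound 1 gives > 20000 nM, which is a limit of the assay, not a number.
- Compound 2, `Nc1nc2c(c(-c3cccs3)cn2[C@@H]2O[C@H](CO)[C@@H](O)[C@H]2O)c(=O)[nH]1`: compound 2 gives > 20000 nM, again a limit rather than a number.
- Compound 3, `CN(C)c1ncnc2c1c(-c1cc3ccccc3o1)cn2[C@@H]1O[C@H](CO)[C@@H](O)[C@H]1O`: compound 3 gives > 20000 nM, also a limit.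

Compound 1 therefore stands at the edge of what this assay can report: none of the three compounds gives a number, and all sit at the limit of > 20000 nM in this assay, at which 3 of the 3 values shown sit. The one step that joins two of these compounds, a step that the two limits leave unreadable from compound 1 to compound 2, cannot be read in size or direction because both ends are limits.

The unmeasured compound 4, `O=c1[nH]cnc2c1c(-c1ccccc1)cn2[C@@H]1O[C@H](CO)[C@@H](O)[C@H]1O`, differs from compound 1 in one place: phenyl in place of thiophen-2-yl on an aromatic carbon. For the measured compounds named here, no measured step touches this kind of change, so nothing here speaks for or against a shift beyond the scatter. Since compound 1 sits at the limit of > 20000 nM in this assay, at which 3 of the 3 values shown sit, compound 4 is expected to stay at the same limit, and the step of a number no higher from compound 1 to compound 4 (the limit leaves the size open) is an estimate with no measured support. The expected value for compound 4 is 20000 nM, between 6000 nM and 40000 nM.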

Compound 4, half-maximal inhibitory concentration: > 20000 nM
Compound 4 ended at the assay's limit; the forecaster's own chance of this, stated with the estimate: 80%; the middle value sits exactly at the limit.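

The step from compound 1 to compound 4 cannot be read, since each compound ends at a limit of the assay and not at a number. The compounds shown leave open whether any change to the shared core would give a measurable value: the limit of > 20000 nM in this assay, at which 4 of the 4 values shown sit.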